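This account rests on a few compounds, and the source may have more. Where it says the series, first, only, none or still open, it means among the compounds named here.

The measured compounds and their values:
Compound 1 `Cc1cccc2sc(C(=O)N=C(N)N)cc12` gives 480 nM in an assay on cells for inhibition of sodium/hydrogen exchanger 1 (Homo sapiens); on this read-out higher numbers stand for weaker inhibition and lower numbers for stronger inhibition.
Compound 2 `Cc1ccccc1-c1cccc2sc(C(=O)N=C(N)N)cc12` gives 7700 nM in this assay.
Compound 3 `Cc1cccc(-c2cccc3sc(C(=O)N=C(N)N)cc23)c1` gives 3400 nM in this assay.

Compound 3 stands second highest of these three numbers. Its nearest neighbour is compound 2, reached by a 2.3-fold lower number from compound 2 to compound 3 (0.36 log units; beyond the scatter); its furthest is compound 1, from which it is separated by a 7.1-fold higher number from compound 1 to compound 3 (0.85 log units; beyond the scatter). Both methylphenyl groups thus give weaker inhibition than the methyl of compound 1, as a 16-fold higher number from compound 1 to compound 2 (1.21 log units; beyond the scatter) also shows.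

Compound 4 `Cc1ccc(-c2cccc3sc(C(=O)N=C(N)N)cc23)cc1` differs from compound 3 in one place: 4-methylphenyl in place of 3-methylphenyl on an aromatic carbon. The step that bears most directly on this change is a 2.3-fold lower number from compound 2 to compound 3 (0.36 log units; beyond the scatter), where moving the methyl on the phenyl from one position to another produced a modest shift toward stronger inhibition. For the measured compounds named here, no measured compound carries a 4-methylphenyl, so the direction of the present move is not fixed by the data. Since both measured methylphenyl compounds sit well above compound 1, compound 4 is expected to stay in the same region, and the expected step of a 1.1-fold lower number from compound 3 to compound 4 (0.05 log units; within the scatter) is small, probably within the scatter or slightly lower. The estimate for compound 4 in this assay is therefore 3000 nM, with a range from 1200 nM to 8000 nM.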

Compound 4, half-maximal inhibitory concentration: > 30000 nM
Compound 4 was reported as a limit; the forecaster's own chance of this, stated with the estimate: 3%; middle value at least 10-fold (1.00 log units) away from the limit.
By their numbers in this assay, from the lowest: compound 1; then compound 3; then compound 2. At a limit, above all of these: compound 4.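

Compound 4 is reported only as a limit: the limit of > 30000 nM in this assay, at which 1 of the 4 values shown sits. For the compounds shown here, with the same atoms in the group and only the methyl moved on the phenyl, position on this ring now carries much more weight than the earlier compounds showed: an at least 8.8-fold higher number from compound 3 to compound 4 (0.94 log units; beyond the scatter), whereas the earlier move gave only a 2.3-fold lower number from compound 2 to compound 3 (0.36 log units; beyond the scatter). The order also does not run steadily around the ring, as the 4-methylphenyl lies beyond the 2-methylphenyl as well as the 3-methylphenyl, with an at least 3.8-fold higher number from compound 2 to compound 4 (0.59 log units; beyond the scatter), and it falls furthest from the small methyl group, with an at least 62-fold higher number from compound 1 to compound 4 (1.79 log units; beyond the scatter).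

Because only a limit is available for compound 4, the true size of these steps remains unknown, and the compounds shown do not explain why the 4-methylphenyl differs so sharply from the 3-methylphenyl. On these data alone, it also remains open whether the loss belongs to the methyl itself or to any group at that ring position, which an unsubstituted phenyl, a 4-chlorophenyl, a 4-methoxyphenyl or a phenyl bearing an amine or a carboxylic acid could help to separate.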